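A Bromo Substituent Tried Where Carboxy Gave No Signal

This account rests on a few compounds, and the source may have more. Where it says the series, first, only, none or still open, it means among the compounds named here.

Compound 1, `Cc1cccc(N2C(=O)N/C(=C\c3ccc(O)cc3)C2=O)c1`, reaches only the assay limit of > 200000 nM in a functional assay on NCI-H292 cells (Homo sapiens) for antiproliferative activity; a lower number here means a stronger inhibitor, a higher number a weaker inhibitor.
Compound 2, `O=C(O)c1ccc(N2C(=O)N/C(=C\c3ccc(O)cc3)C2=O)cc1`, reaches only the assay limit of > 200000 nM in this assay.

Compound 2 therefore stands at no measured number at all; it sits at the limit of > 200000 nM in this assay, at which 2 of the 2 values shown sit. Among the compounds with values here, with both measured compounds at the limit, no ordering between them can be read, and no step between measured compounds is available to guide the next change.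

Compound 3, `O=C1N/C(=C\c2ccc(O)cc2)C(=O)N1c1ccc(Br)cc1`, differs from compound 2 by bromo in place of carboxy on an aromatic carbon. Since nothing above the limit has been seen with this shared core, and the change touches only the group para to a large group, no movement beyond the scatter in this assay is expected in either direction; the step from compound 2 to compound 3 is estimated as an at least 1.3-fold lower number from compound 2 to compound 3 (0.12 log units; that floor lies within the scatter). Compound 3 is thus expected to give roughly 150000 nM, somewhere between 30000 nM and 600000 nM, most likely again reported only as a limit.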

Compound 3, half-maximal inhibitory concentration: 69900 nM
Beside the measured number, compound 3's estimate is 2.1-fold (0.33 log units) above it; low and high end bracket the measured number.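

In this assay, the group para to a large group on the aromatic ring now shows that this series can yield a measured number: bromo in place of carboxy gives an at least 2.8-fold lower number from compound 2 to compound 3 (0.45 log units; beyond the scatter). The wider change of 4-bromophenyl in place of 3-methylphenyl on the amide-type nitrogen gives an at least 2.8-fold lower number from compound 1 to compound 3 (0.45 log units; beyond the scatter), but it alters both the group and where it sits, so it cannot show which of the two matters. Both steps are floors and not full sizes, as compounds 1 and 2 each remain a limit and not a number: the limit of > 200000 nM in this assay, at which 2 of the 3 values shown sit.

On these data alone, it remains open whether the measured number of compound 3 depends on bromo itself or simply on the absence of carboxy and methyl, as the three compounds cannot separate these readings. Also open, as far as these compounds go, is whether chloro, an amine or a methoxy group at the same aromatic carbon would give a lower number, a higher one or a return to the limit, and whether changes elsewhere on the shared core would add to the effect of bromo.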